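This account rests on a few compounds, and the source may have more. Where it says the series, first, only, none or still open, it means among the compounds named here.

Measured compounds and values:
- compound 1, `Nc1ccccc1NC(=O)c1ccc(CSC(=S)N2CCc3ccc([N+](=O)[O-])cc32)cc1`, 39.6%
- compound 2, `Nc1ccccc1NC(=O)c1ccc(CSC(=S)N2CCN(C(c3ccccc3)c3ccccc3)CC2)cc1`, 9.9%
- compound 3, `Nc1ccccc1NC(=O)c1ccc(CSC(=S)N2CCN(Cc3cccnc3)CC2)cc1`, 64.6%

In a functional assay on MGC-803 cells (Homo sapiens) for antiproliferative activity, read by CCK-8 assay, with a stated time of 72 h, tested at 8 uM (on this read-out higher numbers stand for a stronger effect at the one concentration tested and lower numbers for a weaker effect), compound 1 gives 39.6%, which is the second highest of the three numbers. The nearest is compound 3 with 64.6%, a higher number and beyond the usual scatter. The furthest is compound 2 with 9.9%, a lower number and also beyond the scatter. Compound 1 therefore sits between the other two on this read-out.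

Compound 4, `Nc1ccccc1NC(=O)c1ccc(CSC(=S)N2CCc3ccccc32)cc1`, has not yet been measured in this assay. It differs from compound 1 in one place: hydrogen in place of nitro on an aromatic carbon. The nitro group leaves and a hydrogen atom enters on an aromatic carbon of the fused ring system.

Within the data shown here, no measured pair shows the effect of this change, so the step is expected rather than known. A moderate step downward, or none beyond the scatter, is expected from compound 1 to compound 4, that is a number 7.6 percentage points lower from compound 1 to compound 4 (within the scatter). Compound 4 is therefore estimated at 32%, within a range from 12% to 55%.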

Compound 4, a percentage reported as inhibition, at one concentration (the size of the read-out at that concentration, not a potency): 87%
Compound 4: the middle estimate sits 55 percentage points below what was measured; the measured number lies above the stated range.
By their numbers in this assay, from the lowest: compound 2; then compound 1; then compound 3; then compound 4.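

In this assay, hydrogen in place of nitro on this aromatic carbon gives a number 47.4 percentage points higher from compound 1 to compound 4 (beyond the scatter), so the read-out responds strongly to what this position carries. The earlier compounds shown here differed from one another in more than one place and could not show this; this pair shows that the nitro group is not needed for the effect at the one concentration tested and that, on this core, it goes with the lower number. Nothing available explains why this change has so large an effect.

The compounds shown carry only nitro or hydrogen at this carbon, so it remains open where an amine, a methoxy group or a chlorine atom there would fall. They also leave open whether nitro on another carbon of this ring would give a similar step.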